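The compounds below may be only part of what the source reports. "The series", "measured", "known", "first", "only" and "open" are said of these compounds alone.

Measured so far in an assay on isolated protein for inhibition of tyrosine-protein kinase receptor UFO (Homo sapiens), with a stated time of 1.5 h; a lower number here means a stronger inhibitor, a higher number a weaker inhibitor:
compound 1, `COc1ccc(-n2cc(-c3n[nH]c4cc(Cl)c(N[C@@H]5CCNC5)cc34)cn2)cc1`, gives 300 nM
compound 2, `Cn1cc(-c2n[nH]c3cc(Br)ccc23)cn1`, gives 950 nM
compound 3, `CN1CC[C@@H](Nc2cc3c(-c4cnn(C)c4)n[nH]c3cc2Cl)C1`, gives 74000 nM

Compound 2 stands second highest of the three numbers in this assay. Its nearest neighbour is compound 1, whose number is lower by a margin beyond the scatter; compound 3 lies far above it, also beyond the scatter. Within the data shown here, no pair among the three measured compounds differs in a single place, so no measured step is available to lean on, and the two other compounds carry further substituents on the shared core that compound 2 lacks.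

Compound 4, `Cn1cc(-c2n[nH]c3cc(-c4ccccc4)ccc23)cn1`, is still to be measured in this assay. Against compound 2 the change is phenyl in place of bromo on an aromatic carbon. Nothing measured here isolates that exchange. The expectation is a step of modest size, more likely downward in number than upward, with a real possibility of no change beyond the scatter. Compound 4 is expected at 450 nM, within 120 nM to 1800 nM. The step from compound 2 to compound 4 is estimated as a 2.1-fold lower number from compound 2 to compound 4 (0.32 log units; beyond the scatter).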

Compound 4, half-maximal inhibitory concentration: 12300 nM
For compound 4 the middle estimate is 27-fold (1.44 log units) below the measured one; the whole stated range lies below it.
By their numbers in this assay, from the lowest: compound 1; then compound 2; then compound 4; then compound 3.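

In this assay, among these compounds, phenyl in place of bromo on an aromatic carbon gives a 13-fold higher number from compound 2 to compound 4 (1.11 log units; beyond the scatter) and this is the only single-place step at hand. The position, meta to a fused ring and para to a fused ring, therefore does not tolerate every exchange: the change points towards a weaker inhibitor and lies beyond the scatter, even though neither group brings hydrogen-bond donors, hydrogen-bond acceptors or a net charge. No measurement available here accounts for the size of this step.

As far as these compounds go, two groups at one position define no trend, so it remains open whether a small group such as methyl or chloro would stay close to bromo, or whether a phenyl ring carrying an amine or a carboxylic acid would recover any of the lost strength. From the compounds shown here alone, it also remains open whether the same exchange would give a step of similar size and direction on a core carrying the further substituents seen in compound 1 and compound 3.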